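Vinyl for methyl on the shared core: hepatic extraction

The source may hold more compounds than are shown below. What is called first, only, known or untested is meant among the compounds shown, and "the series" means these compounds.

Working notes on the series. In an ADME assay on microsomes from liver (Homo sapiens), read by LC-MS, with a stated time of 90 min (on this read-out lower numbers stand for lower hepatic extraction and higher numbers for higher hepatic extraction), compound 1 `CC[C@H](C)n1c(=O)[nH]c2ncc(Br)nc21` returns only a limit, < 0.2. For compound 2 `O=c1[nH]c2ncc(Br)nc2n1C1CCCCC1` this assay gives "not determined" (no result reported). Compound 3 `CCC(CC)n1c(=O)[nH]c2ncc(C)nc21` likewise sits at a limit in this assay, < 0.2. Among the compounds with values here, compound 3 therefore stands at the assay limit shared with one other compound (the limit of < 0.2 in this assay, at which 2 of the 3 values shown sit), and no measured step between neighbours exists to anchor the size of a change. Compound 4 `C=Cc1cnc2[nH]c(=O)n(C(CC)CC)c2n1` differs from compound 3 by a single change: vinyl in place of methyl on an aromatic carbon. Within the data shown here, with no step measured, only a small shift is expected in this assay, if any, toward higher hepatic extraction, and a further limit remains likely. The estimate for compound 4 is 0.25, between 0.1 and 0.5, which means an expected step a number at least 0.050 higher from compound 3 to compound 4 (that floor lies within the scatter).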

Compound 4, hepatic extraction ratio: 0.5
For compound 4 the middle estimate is 0.25 below the measured one, within the range that was stated.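

Vinyl in place of methyl on an aromatic carbon gives, in this assay, a number at least 0.30 higher from compound 3 to compound 4 (beyond the scatter). Within the data shown here, this position on the shared core therefore responds to the change, with a step that lies beyond the scatter, and the step is the first one the series can offer. The other readable values give no such size, as they stand at a limit: the limit of < 0.2 in this assay, at which 2 of the 4 values shown sit.

From the compounds shown here alone, whether the step follows the double bond or the added carbon stays open. An ethyl group at this position would separate the two, and an amine there would show whether the response extends beyond carbon groups.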